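Pyrrolidinone substituent series: cytotoxicity notes toward compound 4

The source may hold more compounds than are shown below. What is called first, only, known or untested is meant among the compounds shown, and "the series" means these compounds.

Compound 1, `O=C1CC(Oc2ncccn2)CN1c1cnn2c1CN(C(=O)Nc1cc(F)c(F)c(F)c1)C(C1CC1)C2`: in a toxicity assay on HepG2 2.2.15 cells (Homo sapiens) for cytotoxicity, read by CellTiter-Glo (on this read-out lower numbers stand for higher toxicity in this test and higher numbers for lower toxicity in this test), compound 1 reaches only a limit, > 200000 nM.
Compound 2, `O=C1OC(c2ccc(F)cc2)CN1c1cnn2c1CN(C(=O)Nc1cc(F)c(F)c(F)c1)C(C1CC1)C2`: in this assay compound 2 gives 3560 nM.
Compound 3, `CC1(C)CC(=O)N(c2cnn3c2CN(C(=O)Nc2cc(F)c(F)c(F)c2)C(C2CC2)C3)C1`: in this assay compound 3 gives 115000 nM.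

Compound 3 holds the higher of the two numbers; compound 2 sits at the lower one, and the gap between them is beyond the scatter. The third value is a limit only, (the limit of > 200000 nM in this assay, at which 1 of the 3 values shown sits), and it cannot be ordered against the two numbers.

Compound 4, `O=C1CC(c2ccccc2)CN1c1cnn2c1CN(C(=O)Nc1cc(F)c(F)c(F)c1)C(C1CC1)C2`, differs from compound 3 in one place: 2-oxo-4-phenylpyrrolidin-1-yl in place of 4,4-dimethyl-2-oxopyrrolidin-1-yl on an aromatic carbon. The shared core, the urea and the cyclopropyl group stay as they are.

Going by the values given here, no step between measured compounds is available, so the expected direction rests on the two numbers alone. Compound 2, which also carries an aryl group on the five-membered ring, gives 3560 nM, below compound 3. A step toward a lower number, beyond the scatter but not reaching compound 2, is therefore expected for this change.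

The expected step from compound 3 to compound 4 is a 7.7-fold lower number from compound 3 to compound 4 (0.88 log units; beyond the scatter).

Compound 4 is estimated at 15000 nM, with a range from 3000 nM to 70000 nM.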

Compound 4, half-maximal cytotoxic concentration: 12800 nM
Compound 4: middle estimate off by 1.2-fold (0.07 log units), on the high side; the range from low to high includes it.
By their numbers in this assay, from the lowest: compound 2; then compound 4; then compound 3. At a limit, above all of these: compound 1.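

In this assay, the change on the aromatic carbon of the five-membered aromatic ring now has a direct step: a 9.0-fold lower number from compound 3 to compound 4 (0.95 log units; beyond the scatter), with 2-oxo-4-phenylpyrrolidin-1-yl in place of 4,4-dimethyl-2-oxopyrrolidin-1-yl and the rest of the molecule unchanged. A second step stays within the same substituent position, with phenyl in place of (pyrimidin-2-yl)oxy on a saturated ring carbon, and gives an at least 15-fold lower number from compound 1 to compound 4 (1.19 log units; beyond the scatter), so compound 4 now has a lower number than either single-change partner, both steps beyond the scatter. The second step has an open end, since it starts from a value that is only a limit: the limit of > 200000 nM in this assay, at which 1 of the 4 values shown sits.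

The compounds shown leave open whether the lower number follows the aromatic ring itself, as a cyclohexyl or pyridin-3-yl group on the same saturated ring carbon would test. They also leave open whether a benzyl group, which sets a methylene linker between that carbon and the phenyl ring, would give a number closer to compound 3 or to compound 4.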